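Notes on the shared core: compound 3 to compound 4

The source may hold more compounds than are shown below. What is called first, only, known or untested is meant among the compounds shown, and "the series" means these compounds.

Of the compounds shown here, three on the shared core have been measured in a functional assay on DLD-1 cells (Homo sapiens) for cytotoxicity, with a stated time of 48 h; on this read-out lower numbers stand for stronger inhibition and higher numbers for weaker inhibition. Compound 1 `CCOc1ccc2oc(/C=C/[S+](C)[O-])cc(=O)c2c1` gives 4900 nM, compound 2 `C[S+]([O-])/C=C/c1cc(=O)c2ccccc2o1` gives 8000 nM, and compound 3 `CC(C)CC(=O)Oc1ccc2oc(/C=C/[S+](C)[O-])cc(=O)c2c1` gives 6100 nM. Compound 3 thus stands second highest of the three numbers, yet the step of a 1.2-fold higher number from compound 1 to compound 3 (0.10 log units; within the scatter) and the step of a 1.3-fold lower number from compound 2 to compound 3 (0.12 log units; within the scatter) both fall within the scatter, as does a 1.6-fold higher number from compound 1 to compound 2 (0.21 log units; within the scatter), so the three compounds cannot be told apart in this assay.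

Compound 4 `C[S+]([O-])/C=C/c1cc(=O)c2cc(O)ccc2o1` is not yet measured. Its difference from compound 3 is hydrogen in place of isobutylcarbonyl on an oxygen on an aromatic ring. For the measured compounds named here, two measured steps touch the same place: a 1.2-fold higher number from compound 1 to compound 3 (0.10 log units; within the scatter) exchanges the group on that oxygen, and a 1.3-fold lower number from compound 2 to compound 3 (0.12 log units; within the scatter) adds the whole (isobutylcarbonyl)oxy group; neither moved the number beyond the scatter. On that basis the change from (isobutylcarbonyl)oxy to hydroxy is expected to leave this assay about unchanged, with no step beyond the scatter expected in either direction.

Compound 4 is therefore estimated at 6000 nM, with a range from 2500 nM to 15000 nM. The step this estimate means is a 1.0-fold lower number from compound 3 to compound 4 (0.01 log units; within the scatter), expected to fall within the scatter.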

Compound 4, half-maximal inhibitory concentration: > 10000 nM
Compound 4: only a limit was reported (the forecaster's own chance of this, stated with the estimate: 5%); middle value at least 1.6-fold (0.22 log units) away from the limit.
By their numbers in this assay, from the lowest: compounds 1, 3 and 2 (each within the scatter of the next). At a limit, above all of these: compound 4.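

For compound 4, which carries hydroxy on this aromatic carbon, the result is a limit and not a number: the limit of > 10000 nM in this assay, at which 1 of the 4 values shown sits. The steps into compound 4 are floors only, and each floor lies within the scatter: (an at least 1.6-fold higher number from compound 3 to compound 4 (0.21 log units; that floor lies within the scatter)) on removing isobutylcarbonyl from the oxygen, (an at least 1.2-fold higher number from compound 2 to compound 4 (0.09 log units; that floor lies within the scatter)) on setting hydroxy in place of hydrogen, and (an at least 2.0-fold higher number from compound 1 to compound 4 (0.30 log units; that floor lies within the scatter)) on removing ethyl from the oxygen. Ethoxy, (isobutylcarbonyl)oxy and hydrogen at this place gave numbers that could not be told apart, whereas hydroxy is the one group of the four without a number, so a real separation on freeing the hydroxy is possible but not shown.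

The compounds shown leave open how far compound 4 actually lies from the other three, as its true value could sit close to them or well away from them. They also leave open whether an amine, a methoxy group or a longer alkoxy chain on this aromatic carbon would stay with ethoxy and (isobutylcarbonyl)oxy or would go with hydroxy.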